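Trimming a propanoyl to an acetyl on a macrolide

The source may report more compounds than this note shows. Statements on the series, on what has been measured and on what is new or still open speak of the compounds shown alone.

Three macrolides have been compared in a physicochemical assay for lipophilicity, read by HPLC, measured as chromatographic lipophilicity, at pH 7.4; on this read-out higher numbers stand for higher lipophilicity and lower numbers for lower lipophilicity. Compound 1 `CC[C@H]1OC(=O)[C@H](C)[C@@H](O)[C@H](C)[C@@H](O[C@@H]2O[C@H](C)C[C@H](N(C)C)[C@H]2O)[C@](C)(O)C[C@@H](C)CN(C)[C@H](C)[C@@H](O)[C@]1(C)O` gives 1.35. Compound 2 `CCC(=O)NCCCO[C@@H]1[C@@H](C)N(C)C[C@H](C)C[C@@](C)(O)[C@H](O[C@@H]2O[C@H](C)C[C@H](N(C)C)[C@H]2O)[C@@H](C)[C@H](O[C@H]2C[C@@](C)(OC)[C@@H](O)[C@H](C)O2)[C@@H](C)C(=O)O[C@H](CC)[C@@]1(C)O` gives 2.74, the highest of the three numbers, although compound 3 `CC[C@H]1OC(=O)[C@H](C)[C@@H](O[C@H]2C[C@@](C)(OC)[C@@H](OCCCNC(=O)c3c(C)nn(C)c3Cl)[C@H](C)O2)[C@H](C)[C@@H](O[C@@H]2O[C@H](C)C[C@H](N(C)C)[C@H]2O)[C@](C)(O)C[C@@H](C)CN(C)[C@H](C)[C@@H](O)[C@]1(C)O` at 2.52 lies within the usual scatter of that figure, whereas compound 1 lies well beyond it. Compound 4 `CC[C@H]1OC(=O)[C@H](C)[C@@H](O[C@H]2C[C@@](C)(OC)[C@@H](O)[C@H](C)O2)[C@H](C)[C@@H](O[C@@H]2O[C@H](C)C[C@H](N(C)C)[C@H]2O)[C@](C)(O)C[C@@H](C)CN(C)[C@H](C)[C@@H](OCCCNC(C)=O)[C@]1(C)O` has not yet been measured in this assay. It differs from compound 2 by hydrogen in place of methyl on a saturated chain carbon bound to a carbonyl carbon, that is, propanoyl to acetyl, propanoylamino to acetamido. Losing one carbon at such a place is expected to lower lipophilicity only slightly, so the step of a number 0.39 log units lower from compound 2 to compound 4 (beyond the scatter) is expected to be a small drop near the edge of the scatter. Compound 4 is therefore estimated at 2.35, with a range from 1.9 to 2.8.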

Compound 4, distribution coefficient: 2.41
Compound 4: the middle estimate sits 0.06 log units below what was measured; the measured number falls inside the stated range.
By their numbers in this assay, from the lowest: compound 1; then compounds 4, 3 and 2 (each within the scatter of the next, the first and the last beyond it).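

In this assay the change from propanoyl to acetyl gives the first step read at this position, a number 0.33 log units lower from compound 2 to compound 4 (beyond the scatter), which shows that losing this one carbon, on a saturated chain carbon bound to a carbonyl carbon, moves the number by a modest amount. The earlier compounds shown here offered no pair differing in one place, so they could not show this. Nothing at hand accounts for the size of the step. The compounds shown leave open what a longer chain such as butanoyl would give at this place, and whether an amine in place of the acyl group would move the number further.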